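A few compounds are considered here, and "the series" means these few. Any claim that something is new, unique, unknown or untested is made for them only; others in the source may bear on it.

In a physicochemical assay for lipophilicity, read by HPLC, measured as octanol-water partition (a higher number here means a more lipophilic compound, a lower number a more polar compound), compound 1 `Nc1ccccc1C(=O)N/N=C/c1ccc2no[n+]([O-])c2c1` gives 2, and compound 2 `N#Cc1c(-c2ccco2)[n+]([O-])c2ccc(C3OCCO3)cc2[n+]1[O-]` gives 2, which leaves compound 2 level with compound 1 within the scatter. Compound 3 `COc1ccc(-c2c(C#N)[n+]([O-])c3cc(C4OCCO4)ccc3[n+]2[O-])cc1`, not yet measured, departs from compound 2 by one change, 4-methoxyphenyl in place of furan-2-yl on an aromatic carbon. Within the data shown here, no measured pair of compounds differs in a single place, so the expectation rests on the structural change alone. A move towards the more lipophilic end of the scale, beyond the scatter, is expected, with an estimated a number 0.80 log units higher from compound 2 to compound 3 (beyond the scatter). For compound 3 the estimated value is 2.8, within an expected range from 2.3 to 3.4.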

Compound 3, partition coefficient: 1.4
Beside the measured number, compound 3's estimate is 1.40 log units above it; the measured number lies below the stated range.
By their numbers in this assay, from the lowest: compound 3; then compounds 1 and 2 (each within the scatter of the next).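

In this assay, 4-methoxyphenyl in place of furan-2-yl on this aromatic carbon, ortho to a cyano group, gives a number 0.60 log units lower from compound 2 to compound 3 (beyond the scatter) and so shows that the read-out responds to the group held at this position. The entering group has more heavy atoms than the one leaving, yet the number moves down, so heavy-atom count does not set the direction here. Nothing measured on hand accounts for this direction. This single step cannot separate the part played by the methoxy group from that of the six-membered ring. From the compounds shown here alone, whether an unsubstituted phenyl or an amine at this position would fall on the same side stays open.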